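A few compounds are considered here, and "the series" means these few. Any claim that something is new, unique, unknown or untested is made for them only; others in the source may bear on it.

Compound 3 `C=CCn1c(=O)/c(=C\c2cc(F)ccc2C)[nH]c(=O)/c1=C\c1ccccc1OC` stands at the lowest of the three numbers seen so far in a functional assay on NCI-H1975 cells (Homo sapiens) for cytotoxicity, read by CCK-8 assay, with a stated time of 72 h (on this read-out lower numbers stand for stronger inhibition and higher numbers for weaker inhibition), where compound 3 gives 7300 nM. Compound 2 `C=CCn1c(=O)/c(=C\c2cccc(F)c2)[nH]c(=O)/c1=C\c1ccccc1OC` gives 25600 nM and compound 1 `C=CCn1c(=O)/c(=C\c2cccc(C)c2)[nH]c(=O)/c1=C\c1ccccc1OC` gives 32800 nM; both steps down to the lowest number are beyond the scatter, namely a 4.5-fold lower number from compound 1 to compound 3 (0.65 log units; beyond the scatter) and a 3.5-fold lower number from compound 2 to compound 3 (0.54 log units; beyond the scatter). Compound 4 `C=CCn1c(=O)/c(=C\c2ccc(F)c(Br)c2)[nH]c(=O)/c1=C\c1ccccc1OC` differs from compound 3 in one place: 3-bromo-4-fluorophenyl in place of 5-fluoro-2-methylphenyl on a double-bonded chain carbon bound to an aromatic carbon. Among the compounds with values here, two measured steps bear on this change. The step of a 3.5-fold lower number from compound 2 to compound 3 (0.54 log units; beyond the scatter) shows what the methyl on an aromatic carbon contributes, and compound 4 no longer carries that methyl. The step of a 1.3-fold lower number from compound 1 to compound 2 (0.11 log units; within the scatter) shows fluoro in place of methyl barely moving the number. A bromo group on the ring has no measured precedent among these compounds. Because the methyl gain behind a 3.5-fold lower number from compound 2 to compound 3 (0.54 log units; beyond the scatter) is undone in compound 4, a modest rise in the number is expected, with wide uncertainty from the untested bromo group; the expected step is a 2.7-fold higher number from compound 3 to compound 4 (0.44 log units; beyond the scatter). Compound 4 is therefore estimated at 20000 nM, within a range from 6000 nM to 60000 nM.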

Compound 4, half-maximal inhibitory concentration: "not active" (no number reported)
The entry for compound 4 holds no number; no gap can be computed for the estimate.
By their numbers in this assay, from the lowest: compound 3; then compounds 2 and 1 (each within the scatter of the next).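

In this assay, within the data shown here, compound 4 is reported as not active, without a number, so no step from compound 3 to compound 4 can be read. Nothing shown here offers an explanation for this result. The compounds shown leave open how the 3-bromo-4-fluorophenyl group would compare in number with the 5-fluoro-2-methylphenyl group.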